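Aryl variation on the dihydropyridine core: predicting compound 4

The source may hold more compounds than are shown below. What is called first, only, known or untested is meant among the compounds shown, and "the series" means these compounds.

Compound 3 `CC1=C(C(=O)OCC2CCN(C(=O)OC(C)(C)C)CC2)C(c2ccc3c(c2)OCCO3)C2=C(CC(C)(C)CC2=O)N1` is the weaker of the two compounds with a number in an assay on HEK293 cells for inhibition of neurogenic locus notch homolog protein 1 (Homo sapiens), read by a luciferase reporter and resazurin assay, with a stated time of 16 h (a higher number here means a weaker inhibitor, a lower number a stronger inhibitor), where compound 3 gives 1520 nM. Its nearest neighbour is compound 1 `CC1=C(C(=O)OCC2CCN(C(=O)OC(C)(C)C)CC2)C(c2cccc(Br)c2)C2=C(CC(C)(C)CC2=O)N1`, for which compound 1 gives 360 nM in this assay; the step of a 4.2-fold higher number from compound 1 to compound 3 (0.63 log units; beyond the scatter) arises from the 2,3-dihydro-1,4-benzodioxin-6-yl group replacing 3-bromophenyl on the saturated ring carbon. Compound 2 `CC1=C(C(=O)OCC2CCN(C(=O)OC(C)(C)C)CC2)C(c2cccc([N+](=O)[O-])c2)C2=C(CC(C)(C)CC2=O)N1` reports only a limit, compound 2 sitting at > 10000 nM in this assay (the limit of > 10000 nM in this assay, at which 1 of the 3 values shown sits). From there, an at least 6.5-fold lower number from compound 2 to compound 3 (0.81 log units; beyond the scatter), with the dihydrobenzodioxinyl group in place of 3-nitrophenyl.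

Compound 4 `CC1=C(C(=O)OCC2CCN(C(=O)OC(C)(C)C)CC2)C(c2cccc(C(C)C)c2)C2=C(CC(C)(C)CC2=O)N1` differs from compound 3 by 3-isopropylphenyl in place of 2,3-dihydro-1,4-benzodioxin-6-yl on a saturated ring carbon. The step from compound 1 to compound 3 is the one that bears most directly on this change: going from 3-bromophenyl to the bicyclic group cost potency beyond the scatter, and compound 4 returns to a singly substituted phenyl ring. The nitro case of compound 2 shows that not every 3-substituted phenyl is tolerated, so the gain is not assured.

Compound 4 is therefore expected to land near compound 1, at 500 nM, with a plausible range from 150 nM to 2500 nM. This estimate corresponds to an expected step of a 3.0-fold lower number from compound 3 to compound 4 (0.48 log units; beyond the scatter).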

Compound 4, half-maximal inhibitory concentration: 3320 nM
Compound 4: the middle estimate sits 6.6-fold (0.82 log units) below what was measured, and the stated range ends below it.
By their numbers in this assay, from the lowest: compound 1; then compound 3; then compound 4. At a limit, above all of these: compound 2.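

In this assay, a singly substituted phenyl ring does not by itself restore the potency of compound 1: isopropyl in place of bromo gives a 9.2-fold higher number from compound 1 to compound 4 (0.96 log units; beyond the scatter), so the result depends on which group the ring carries and not merely on there being one substituent. The 3-isopropylphenyl group also falls behind the bicyclic group, with a 2.2-fold higher number from compound 3 to compound 4 (0.34 log units; beyond the scatter), which places the 2,3-dihydro-1,4-benzodioxin-6-yl compound between the bromo and isopropyl compounds, while isopropyl in place of nitro still gives an at least 3.0-fold lower number from compound 2 to compound 4 (0.47 log units; beyond the scatter). That last step has only a bound because compound 2 is a limit and not a number: the limit of > 10000 nM in this assay, at which 1 of the 4 values shown sits.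

Going by these compounds, with bromo, isopropyl and nitro as the only single substituents on the phenyl ring, no rule connecting these groups to the readings in this assay can be drawn, and the true size of the gap to compound 2 remains unknown. On these data alone, how a 3-chlorophenyl, 3-methoxyphenyl or 3-aminophenyl group would read on the shared core remains open, as does whether moving the bromo group to another ring carbon would keep the value of compound 1.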